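Lengthening the amide substituent from phenyl to 3-phenylpropyl

A few compounds are considered here, and "the series" means these few. Any claim that something is new, unique, unknown or untested is made for them only; others in the source may bear on it.

Of the compounds shown here, two have been measured so far. Compound 1 `COc1ccc(CNC(=O)c2cc3cc(OC)c(OCCCOc4no[n+]([O-])c4S(=O)(=O)c4ccccc4)cc3oc2=O)cc1` gives 560 nM in a functional assay on MCF7 cells (Homo sapiens) for inhibition, read by MTT assay, with a stated time of 48 h (a higher number here means a weaker inhibitor, a lower number a stronger inhibitor), and compound 2 `COc1cc2cc(C(=O)Nc3ccccc3)c(=O)oc2cc1OCCCOc1no[n+]([O-])c1S(=O)(=O)c1ccccc1` gives 740 nM. Among the measured compounds shown here, compound 2 thus stands beside compound 1, the only other measured compound, and the step of a 1.3-fold higher number from compound 1 to compound 2 (0.12 log units; within the scatter) lies within the scatter, so the two numbers cannot be told apart.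

Compound 3 `COc1cc2cc(C(=O)NCCCc3ccccc3)c(=O)oc2cc1OCCCOc1no[n+]([O-])c1S(=O)(=O)c1ccccc1` has not yet been measured. It differs from compound 2 by 3-phenylpropyl in place of phenyl on an amide-type nitrogen. For the measured compounds named here, the only measured step that bears on this position is the one from compound 1 to compound 2, where the 4-methoxybenzyl group was exchanged for phenyl, and that step was within the scatter. A return to a flexible, longer arm on the amide-type nitrogen is therefore expected to leave this assay roughly unchanged, with no direction beyond the scatter. For compound 3 the estimate in this assay is 650 nM, with a range from 300 nM to 1400 nM. The step of a 1.1-fold lower number from compound 2 to compound 3 (0.06 log units; within the scatter) is the expected change, and it is expected to stay within the scatter.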

Compound 3, half-maximal inhibitory concentration: 870 nM
The estimate for compound 3 lay 1.3-fold (0.13 log units) below the measured number; the range from low to high includes it.
By their numbers in this assay, from the lowest: compounds 1, 2 and 3 (each within the scatter of the next).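

Compound 3 brings the first arm on the amide-type nitrogen that is longer than 4-methoxybenzyl, with 3-phenylpropyl carrying 9 heavy atoms where phenyl carries 6. In this assay the step of a 1.2-fold higher number from compound 2 to compound 3 (0.07 log units; within the scatter) and the step of a 1.6-fold higher number from compound 1 to compound 3 (0.19 log units; within the scatter) both lie within the scatter, so all three arms give numbers that cannot be told apart. The earlier pair showed this only for phenyl and 4-methoxybenzyl, whereas the three compounds now extend it to 3-phenylpropyl, and none of them goes against it; no measurement at hand speaks to what lies behind this reading.

All three arms end in a six-membered aromatic ring of carbon only, so the compounds shown leave open whether this reading would hold for an arm ending in an amine or a carboxylic acid, or for a plain alkyl chain with no ring at all. They also leave open whether a longer chain, such as 5-phenylpentyl, would still fall within the scatter of these three.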